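The source may report more compounds than this note shows. Statements on the series, on what has been measured and on what is new or still open speak of the compounds shown alone.

Working notes on the series. Compound 2 `COc1cc2c(Oc3ccc(NC(=O)c4nn(-c5ccccc5)c(=O)c5ccccc45)cc3F)ccnc2cc1OCCCN1CCCCC1` gives 1310 nM in a functional assay on HT-29 cells (Homo sapiens) for cytotoxicity, read by MTT assay, with a stated time of 72 h (a lower number here means a stronger inhibitor, a higher number a weaker inhibitor), the higher of the two numbers at hand. Compound 1 `COc1cc2c(Oc3ccc(NC(=O)c4nn(-c5ccccc5F)c(=O)c5ccccc45)cc3F)ccnc2cc1OCCCN1CCCC1` differs from compound 2 in two places at once; in this assay compound 1 gives 400 nM, a gap that lies beyond the usual scatter. Compound 3 `COc1cc2c(Oc3ccc(NC(=O)c4nn(-c5ccccc5F)c(=O)c5ccccc45)cc3F)ccnc2cc1OCCCN1CCCCC1` is not yet measured; relative to compound 2 the change is fluoro in place of hydrogen on an aromatic carbon. For the measured compounds named here, no single-point step between measured compounds is in hand, so the expected step from compound 2 to compound 3 is a modest move toward a lower number, a 1.7-fold lower number from compound 2 to compound 3 (0.24 log units; within the scatter). In this assay compound 3 is estimated at 750 nM, within 300 nM to 1800 nM.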

Compound 3, half-maximal inhibitory concentration: 630 nM
Beside the measured number, compound 3's estimate is 1.2-fold (0.08 log units) above it, and the stated range covers the measured number.
By their numbers in this assay, from the lowest: compounds 1 and 3 (each within the scatter of the next); then compound 2.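

In this assay, for the compounds shown here, phenyl to 2-fluorophenyl gives a 2.1-fold lower number from compound 2 to compound 3 (0.32 log units; beyond the scatter) and so supplies the first single-change reading at this place, ortho to a large group. Piperidin-1-yl in place of pyrrolidin-1-yl gives a 1.6-fold higher number from compound 1 to compound 3 (0.20 log units; within the scatter) and thus separates the side-chain change from the fluoro change, with the two compounds bearing 2-fluorophenyl not told apart. No measurement at hand bears on the reason for the fluoro step. Open, from the compounds shown here alone, is whether chloro or methoxy at the same place would read like fluoro. Also open, going by these compounds, is whether a morpholine on the chain would stay level with piperidin-1-yl and pyrrolidin-1-yl.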